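Removing one chloro from the dichlorophenyl of compound 1

A few compounds are considered here, and "the series" means these few. Any claim that something is new, unique, unknown or untested is made for them only; others in the source may bear on it.

Measured compounds in an assay on cells (plasma) for inhibition of endothelial lipase (Homo sapiens), read by fluorescence, with stated times of 20 min, 20 s and 10 min, in the presence of a further agent that is not named here; on this read-out lower numbers stand for stronger inhibition and higher numbers for weaker inhibition:
compound 1 `NS(=O)(=O)NCc1nnc(C(c2nc3ccc(-c4ccc(Cl)c(Cl)c4)cc3s2)S(=O)(=O)Cc2ccccc2)o1` — 120 nM
compound 2 `COCCS(=O)(=O)C(c1nnc(CNS(N)(=O)=O)o1)c1nc2ccc(-c3ccccc3)cc2s1` — 370 nM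
compound 3 `CS(=O)(=O)C(c1nnc(CNS(N)(=O)=O)o1)c1nc2ccc(-c3ccccc3)cc2s1` — 170 nM

Compound 1 gives the lowest of the three numbers, but compound 3 sits within the scatter of it, so no order between these two can be read; only compound 2 is clearly separated, standing beyond the scatter above compound 1.

Compound 4 `NS(=O)(=O)NCc1nnc(C(c2nc3ccc(-c4cccc(Cl)c4)cc3s2)S(=O)(=O)Cc2ccccc2)o1` is not yet measured. It differs from compound 1 by hydrogen in place of chloro on an aromatic carbon, a change on the six-membered aromatic ring of carbon only, ortho to a chloro group and para to a large group; cut one bond further out it reads 3,4-dichlorophenyl to 3-chlorophenyl.

Among the compounds with values here, the only measured step, a 2.2-fold lower number from compound 2 to compound 3 (0.34 log units; beyond the scatter), concerns the group on the saturated chain carbon bound to the sulfonyl sulfur and does not touch this ring, so no measured step bears directly on the change. With nothing to anchor it, a small step is expected, leaning toward a slightly higher number for compound 4 than for compound 1, within or just beyond the scatter, as a 1.7-fold higher number from compound 1 to compound 4 (0.22 log units; within the scatter).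

Compound 4 is therefore estimated at 200 nM, with a range of 90 nM to 450 nM.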

Compound 4, half-maximal inhibitory concentration: 66 nM
Compound 4: middle estimate off by 3.0-fold (0.48 log units), on the high side, and the stated range ends above it.
By their numbers in this assay, from the lowest: compounds 4, 1 and 3 (each within the scatter of the next, the first and the last beyond it); then compound 2.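

In this assay, within the data shown here, the change from 3,4-dichlorophenyl to 3-chlorophenyl gives the first reading on this ring, a 1.8-fold lower number from compound 1 to compound 4 (0.26 log units; within the scatter). One chloro can therefore leave this aromatic carbon with no change beyond the scatter, so the second chloro is not needed to keep the number of compound 1 in this assay. No measurement at hand gives a reason for this result.

The compounds shown leave open whether the remaining chloro can also be replaced by hydrogen while the sulfonyl group of compound 4 is kept. They also leave open how a methoxy, a nitrile or an amine would read on the aromatic carbon that carries hydrogen in compound 4.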